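Two Diastereomeric Endoperoxide Acids and Their Growth Inhibition

This account rests on a few compounds, and the source may have more. Where it says the series, first, only, none or still open, it means among the compounds named here.

Compound 1: `CC(=O)CC/C=C(\C)CCC1=C(C)CCCC1(C)C`, 2940 nM
Compound 2: `C=C1CCC[C@H]2[C@](C)(CCC(C)=O)[C@@H](C)CC[C@]12C`, > 15000 nM
Compound 3: `C=C1CCCC(C)(C)C1CC[C@@]1(C)CC[C@H]([C@@H](C)C(=O)O)OO1`, 1760 nM

Of the compounds shown here, three have been measured in a functional assay on CCRF-CEM cells (Homo sapiens) for inhibition; a higher number here means a weaker inhibitor of growth, a lower number a stronger inhibitor of growth. Compound 1 gives 2940 nM in this assay. For compound 2 the result in this assay is a limit, > 15000 nM, not a number; the limit of > 15000 nM in this assay, at which 1 of the 3 values shown sits, describes this. Compound 3 gives 1760 nM in this assay, and this number and that of compound 1 lie within the usual scatter of one another, so no order between them can be read from the data.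

Compound 4, `C=C1CCCC(C)(C)C1CC[C@]1(C)CC[C@@H]([C@@H](C)C(=O)O)OO1`, has not yet been measured. It differs from compound 3 as follows: the two compounds have the same atoms and bonds; at least one stereo element is drawn with a configuration in one of them and without one in the other: 2 of 4 stereo elements differ; a stereocentre at a saturated ring carbon is drawn S in compound 3 and R in compound 4; a stereocentre at a saturated ring carbon is drawn R in compound 3 and S in compound 4. Going by the values given here, no step between two measured compounds of this kind is available, so the size and direction of the change cannot be drawn from the data at hand. An inversion of two stereocentres on the shared core may move the number in either direction or leave it within the scatter; with nothing measured to anchor the direction, the expectation for compound 4 rests close to compound 3 with a wide range.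

Compound 4 is therefore estimated at 2500 nM in this assay, between 700 nM and 9000 nM. The step from compound 3 to compound 4 that this estimate implies is a 1.4-fold higher number from compound 3 to compound 4 (0.15 log units; within the scatter).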

Compound 4, concentration for 50% growth inhibition: 2270 nM
Beside the measured number, compound 4's estimate is 1.1-fold (0.04 log units) above it; measured number inside the range.
By their numbers in this assay, from the lowest: compounds 3, 4 and 1 (each within the scatter of the next). At a limit, above all of these: compound 2.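

In this assay, going by these compounds alone, the exchange of the two stereocentres at saturated ring carbons, drawn S and R in compound 3 and R and S in compound 4, gives the first step on this shared core: a 1.3-fold higher number from compound 3 to compound 4 (0.11 log units; within the scatter). With the atoms and bonds unchanged, this change produces no difference that can be separated from the usual scatter of repeated measurements, so no order between the two compounds can be read, and the data give no sign that the number depends on the configuration at these two places. The reading needs one caution, since the comparison rests on drawings that are not equally defined: the fact that one of compounds 3 and 4 is drawn with a defined configuration and the other without, at the place where they differ

From the compounds shown here alone, whether a methyl ester, a primary amide or a primary alcohol in place of the carboxylic acid shared by compound 3 and compound 4 would move the number remains open, as does the effect of inverting only one of the two stereocentres. Within the data shown here, compound 2 stands at a limit, > 15000 nM, and no step connects it to any of the other compounds.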